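This account rests on a few compounds, and the source may have more. Where it says the series, first, only, none or still open, it means among the compounds named here.

In an ADME assay on microsomes from liver (Mus musculus) for metabolic stability, with a stated time of 10 min (a lower number here means that less of the compound is left, a higher number that more of the compound is left), compound 1 `O=C(O)C12CCC(C(=O)N3CC[C@](c4ccc(C(F)(C(F)(F)F)C(F)(F)F)cc4)(S(=O)(=O)c4ccc(F)cc4)C3)(CC1)CC2` gives 73%, the only number shown for it there, alongside one further entry that carries no single number. Compound 2 `O=C1NC(=O)C2(CCC(C(=O)N3CC[C@](c4ccc(C(F)(C(F)(F)F)C(F)(F)F)cc4)(S(=O)(=O)c4ccc(F)cc4)C3)CC2)N1` gives 81%; 82% (2 entries) in this assay, values that sit within the scatter of compound 1. Compound 3 `O=C(N1CC[C@](c2ccc(C(F)(C(F)(F)F)C(F)(F)F)cc2)(S(=O)(=O)c2ccc(F)cc2)C1)C1(O)CCS(=O)(=O)CC1` differs from compound 1 by a group of 9 heavy atoms (5 carbon, 3 oxygen, 1 sulfur; one six-membered non-aromatic ring with 1 hetero atom) in place of a group of 11 heavy atoms (9 carbon, 2 oxygen; 2 six-membered non-aromatic rings of carbon only), on a carbonyl carbon. Within the data shown here, no step between measured compounds covers such a change, so its effect in this assay is open; the expected step of a number 7 percentage points lower from compound 1 to compound 3 (within the scatter) is taken to stay within the usual scatter, leaning slightly downward. Compound 3 is therefore estimated at 66%, between 42% and 88%.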

Compound 3, percent of the compound remaining: 90%
Compound 3: middle estimate off by 24 percentage points, on the low side, and the stated range ends below it.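

In this assay, 4-hydroxy-1,1-dioxothian-4-yl on the carbonyl carbon gives a number 17 percentage points higher from compound 1 to compound 3 (beyond the scatter), the first step shown at this place. One six-membered ring with a hetero atom can therefore stand there instead of two six-membered rings of carbon only, with more of the compound left. Nothing measured here explains the rise.

The whole group changes in this one step, leaving open whether the hydroxy group or the ring sulfur with its two oxygens matters. As far as these compounds go, how an amine or an open alkyl chain would read at this place also remains open.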